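Amino for hydrogen on a dichloro-less purine core

This account rests on a few compounds, and the source may have more. Where it says the series, first, only, none or still open, it means among the compounds named here.

Measured compounds:
- compound 1 `ClCc1ccccc1Cn1cnc2c(Cl)nc(Cl)nc21`: 1470 nM
- compound 2 `ClCc1ccccc1Cn1cnc2c(Cl)ncnc21`: 16600 nM
- compound 3 `ClCc1cccc(Cn2cnc3c(Cl)ncnc32)c1`: 3460 nM

In a functional assay on KM12 cells (Homo sapiens) for cytotoxicity, read by sulforhodamine B assay, with a stated time of 48 h (on this read-out higher numbers stand for weaker inhibition of growth and lower numbers for stronger inhibition of growth), compound 2 gives 16600 nM, the highest number of the three measured compounds. Compound 3 gives 3460 nM and compound 1 gives 1470 nM. Within the data shown here, the one single-point step that has been measured, an 11-fold higher number from compound 1 to compound 2 (1.05 log units; beyond the scatter), concerns the same position of the shared core that is changed here: it shows what happens when a chloro group at that carbon is replaced by hydrogen.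

Compound 4 `Nc1nc(Cl)c2ncn(Cc3ccccc3CCl)c2n1` takes the opposite direction from compound 2 and fills that position again, this time with a different group: amino in place of hydrogen on an aromatic carbon. Among the measured compounds shown here, the measured step from compound 1 to compound 2 shows that this carbon is sensitive to substitution, but no measured pair shows an amino group there, so the size and direction for an amino group cannot be read from the data. Given that sensitivity, a step of some size is plausible, and the expectation leans toward a lower number than compound 2, but with wide uncertainty. The expected step is a 2.1-fold lower number from compound 2 to compound 4 (0.32 log units; beyond the scatter). Compound 4 is therefore estimated at 8000 nM, within a range of 2000 nM to 30000 nM.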

Compound 4, concentration for 50% growth inhibition: 15500 nM
Compound 4: the middle estimate sits 1.9-fold (0.29 log units) below what was measured, and the stated range covers the measured number.
By their numbers in this assay, from the lowest: compound 1; then compound 3; then compounds 4 and 2 (each within the scatter of the next).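

In this assay, putting amino on this carbon between two ring nitrogen atoms does not separate it from hydrogen (a 1.1-fold lower number from compound 2 to compound 4 (0.03 log units; within the scatter)). Set against chloro at the same carbon, amino gives a large step (an 11-fold higher number from compound 1 to compound 4 (1.02 log units; beyond the scatter)), in the same direction as the earlier step to hydrogen (an 11-fold higher number from compound 1 to compound 2 (1.05 log units; beyond the scatter)), so the sensitivity of this carbon is not simply a matter of whether a group fills it: among compound 1, compound 2 and compound 4, only the chloro group goes with the lower number. Nothing available here accounts for this difference between chloro and amino at this carbon.

The compounds shown leave open whether any other group at this carbon, such as bromo, fluoro, methyl, methoxy or dimethylamino, would match chloro or fall with hydrogen and amino. They also leave open whether amino would behave the same way with the chloromethyl group placed as in compound 3, and whether replacing the chloro group that remains on the ring of compound 4 with an amine or a methoxy group would shift the number.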